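Epimerising the aminomethyl iminosugar for alpha-galactosidase inhibition

The source may report more compounds than this note shows. Statements on the series, on what has been measured and on what is new or still open speak of the compounds shown alone.

Compound 1 `NC[C@@H]1NC[C@H](O)[C@H](O)[C@H]1O` is the plain aminomethyl iminosugar of this set. In an assay on isolated protein for inhibition of alpha-galactosidase (Coffea arabica), read by spectrophotometry, tested at 100 uM (on this read-out higher numbers stand for more inhibition at the one concentration tested (going by the name of the read-out) and lower numbers for less inhibition), compound 1 gives 13%, the lowest of the three numbers. The two cinnamamide-bearing analogues sit well above it: compound 2 `COc1ccc(OC)c(/C=C/C(=O)NC[C@H]2NC[C@H](O)[C@@H](O)[C@H]2O)c1` gives 57% and compound 3 `O=C(/C=C/c1cccc(Br)c1)NC[C@H]1NC[C@H](O)[C@@H](O)[C@H]1O` gives 56%, both beyond the scatter relative to compound 1. Compound 4 `NC[C@H]1NC[C@H](O)[C@H](O)[C@H]1O` keeps every atom and bond of compound 1 and changes only one point of configuration: the two compounds have the same atoms and bonds and differ only in configuration as drawn: 1 of 4 stereo elements differ; a stereocentre at a saturated ring carbon is drawn S in compound 1 and R in compound 4. Going by the values given here, no pair of measured compounds differs by a single stereocentre alone, so the direction of such a change in this assay cannot be read from the data; a moderate shift in either direction would not surprise. Compound 4 is expected to give 25%, with a range from 5% to 60%, meaning an estimated step of a number 12 percentage points higher from compound 1 to compound 4 (beyond the scatter).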

Compound 4, a percentage reported as inhibition, at one concentration (the size of the read-out at that concentration, not a potency): "not active" (no number reported)
Compound 4 has no reported number here, and the estimate cannot be compared.
By their numbers in this assay, from the lowest: compound 1; then compounds 3 and 2 (each within the scatter of the next).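

Going by these compounds alone, compound 4 is reported only as "not active", without a number, so no step from compound 1 to compound 4 can be read. The compounds shown leave open how far inhibition shifts with this single stereocentre, the only contrast in the pair: the fact that compounds 1 and 4 differ only in the configuration as drawn.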